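Adding a second chloro to the core of compound 1

This account rests on a few compounds, and the source may have more. Where it says the series, first, only, none or still open, it means among the compounds named here.

Compound 1 `ClCc1cccc(Cn2cnc3ncnc(Cl)c32)c1`: 6600 nM
Compound 2 `ClCc1cccc(Cn2cnc3c(Cl)nc(Cl)nc32)c1`: 27500 nM
Compound 3 `ClCc1ccccc1Cn1cnc2ncnc(Cl)c21`: 57500 nM

In a functional assay on A498 cells (Homo sapiens) for cytotoxicity, read by sulforhodamine B assay, with a stated time of 48 h (a higher number here means that more compound is tolerated, a lower number that less compound is tolerated), compound 1 gives the lowest of the three numbers, so it is the least tolerated compound among those measured. Compound 2 and compound 3 each differ from compound 1 in more than one place, so their values only show that both are tolerated at higher concentrations than compound 1.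

Compound 4 `ClCc1cccc(Cn2cnc3nc(Cl)nc(Cl)c32)c1` carries chloro in place of hydrogen on an aromatic carbon, the new group sitting between two ring nitrogen atoms, meta to the existing chloro group. No single-point change of this kind is available among the measured compounds. Compound 4 is expected to land near compound 1, with an estimated step of a 1.8-fold higher number from compound 1 to compound 4 (0.26 log units; within the scatter), leaning toward a somewhat higher number. For compound 4 the estimate is 12000 nM, within 4000 nM to 40000 nM.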

Compound 4, concentration lethal to 50% of the cells: 5370 nM
Beside the measured number, compound 4's estimate is 2.2-fold (0.35 log units) above it, within the range that was stated.
By their numbers in this assay, from the lowest: compounds 4 and 1 (each within the scatter of the next); then compound 2; then compound 3.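

In this assay, chloro in place of hydrogen on an aromatic carbon, between two ring nitrogen atoms, gives the study's first readable single-place step, a 1.2-fold lower number from compound 1 to compound 4 (0.09 log units; within the scatter). At this position, then, the added chloro group leaves compound 4 indistinguishable from compound 1 in this read-out. Nothing available explains this result. The compounds shown leave open whether an amine or a methoxy group at the same position would also stay within the scatter. They also leave open whether the chloro group would behave the same way on another benzyl substitution pattern.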